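Working notes: methoxy for methyl, compound 3 to compound 4

A few compounds are considered here, and "the series" means these few. Any claim that something is new, unique, unknown or untested is made for them only; others in the source may bear on it.

In a functional assay on Hep 3B2 cells (Homo sapiens) for antiproliferative activity, read by MTT assay, with a stated time of 24 h, tested at 0.05 ug/mL (a lower number here means a weaker effect, a higher number a stronger effect of the compound at the concentration tested), compound 3 `Cc1ccc2nc(C(=O)Nc3c(F)cc(-c4cccc(F)c4)cc3F)c(C)c(C(=O)O)c2c1` gives 2.11%, the highest of the three numbers recorded, though its gaps to the other two lie within the scatter. Compound 1 `Cc1ccc2nc(C(=O)Nc3c(F)cc(-c4cccc(F)c4)cc3F)c(C)c(O)c2c1` gives 1.52% and compound 2 `Cc1c(C(=O)Nc2c(F)cc(-c3cccc(F)c3)cc2F)nc2ccc(C(F)(F)F)cc2c1O` gives 1.35% in this assay. The two measured steps are a number 0.2 percentage points lower from compound 1 to compound 2 (within the scatter) and a number 0.6 percentage points higher from compound 1 to compound 3 (within the scatter), neither beyond the scatter. Compound 4 `COc1ccc2nc(C(=O)Nc3c(F)cc(-c4cccc(F)c4)cc3F)c(C)c(C(=O)O)c2c1` differs from compound 3 in one place: methoxy in place of methyl on an aromatic carbon. Going by the values given here, no measured step covers a methoxy-for-methyl swap; the only change at that same aromatic carbon is a number 0.2 percentage points lower from compound 1 to compound 2 (within the scatter), which stayed within the scatter, so no step beyond the scatter is expected in this assay for compound 4. Compound 4 is therefore estimated at 2%, within 0.3% to 4.5%, a step of a number 0.1 percentage points lower from compound 3 to compound 4 (within the scatter) expected.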

Compound 4, a percentage reported as inhibition, at one concentration (the size of the read-out at that concentration, not a potency): -0.66%
The estimate for compound 4 lay 2.7 percentage points above the measured number; the whole stated range lies above it.
By their numbers in this assay, from the lowest: compounds 4, 2, 1 and 3 (each within the scatter of the next).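

In this assay, methoxy in place of methyl on this aromatic carbon brings in an oxygen and a hydrogen-bond acceptor, yet gives a number 2.8 percentage points lower from compound 3 to compound 4 (within the scatter). With a number 0.2 percentage points lower from compound 1 to compound 2 (within the scatter), from the trifluoromethyl change at the same carbon, neither of the two replacements of methyl there moves the number beyond the scatter, though compounds 2 and 4 differ from their parents on different cores. Nothing available bears on the reason for this result.

From the compounds shown here alone, whether an amine or ethoxy at this carbon would give a step beyond the scatter remains open. So does whether this position separates the compounds at a higher concentration.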